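Propoxy in place of pyrrolidinyl: an estimate for compound 3

The source may report more compounds than this note shows. Statements on the series, on what has been measured and on what is new or still open speak of the compounds shown alone.

Compound 1: `N#Cc1ccccc1/C=N/Nc1nc(N)c2ncn([C@@H]3O[C@H](CO)[C@@H](O)[C@H]3O)c2n1`, 2.9 nM
Compound 2: `Nc1nc(N/N=C/c2ccc(N3CCCC3)cc2)nc2c1ncn2[C@@H]1O[C@H](CO)[C@@H](O)[C@H]1O`, 5.1 nM

Both were measured in an assay on CHO-K1 cells for displacement of a labelled ligand from adenosine receptor A1 (Homo sapiens), read by scintillation counting, with a stated time of 60 min; on this read-out higher numbers stand for weaker inhibition and lower numbers for stronger inhibition. Compound 2 gives 5.1 nM, the higher of the two numbers, but the step of a 1.8-fold higher number from compound 1 to compound 2 (0.25 log units; within the scatter) lies within the scatter, so compound 1 and compound 2 cannot be separated on these data. Compound 3, `CCCOc1ccc(/C=N/Nc2nc(N)c3ncn([C@@H]4O[C@H](CO)[C@@H](O)[C@H]4O)c3n2)cc1`, has not yet been measured. It differs from compound 2 in one place: propoxy in place of pyrrolidin-1-yl on an aromatic carbon. Going by the values given here, only one measured step touches the same part of the molecule, the exchange of the aryl substituent from compound 1 to compound 2, and that step stayed within the scatter. On that basis no step beyond the scatter is expected in this assay for compound 3, in either direction. The expected step is a 1.1-fold lower number from compound 2 to compound 3 (0.05 log units; within the scatter). Compound 3 is therefore estimated at 4.5 nM, with a range from 1.5 nM to 14 nM.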

Compound 3, inhibition constant: > 10000 nM
Compound 3 was reported as a limit (the forecaster's own chance of this, stated with the estimate: 2%); middle value at least 2200-fold (3.34 log units) away from the limit.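

In this assay, the substituent on this aromatic carbon, para to a large group, proves far from interchangeable: propoxy in place of pyrrolidin-1-yl gives an at least 1900-fold higher number from compound 2 to compound 3 (3.29 log units; beyond the scatter), whereas the earlier exchange of the aryl group, a 1.8-fold higher number from compound 1 to compound 2 (0.25 log units; within the scatter), showed no separable difference. The comparison with the 2-cyanophenyl group gives a gap of the same order, an at least 3400-fold higher number from compound 1 to compound 3 (3.53 log units; beyond the scatter), so 4-propoxyphenyl stands apart from both other aryl groups shown. The number for compound 3 is a limit and not a measured value: the limit of > 10000 nM in this assay, at which 1 of the 3 values shown sits.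

The compounds shown leave open how far compound 3 lies past that limit. They also leave open whether the step goes with the oxygen or with the length of the chain, which a methoxy group or an open-chain dimethylamino group on the same aromatic carbon would help to separate.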